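Fluoro in place of methyl: compound 3 to compound 4

The source may report more compounds than this note shows. Statements on the series, on what has been measured and on what is new or still open speak of the compounds shown alone.

In a functional assay on MDA-MB-231 cells (Homo sapiens) for antiproliferative activity, read by MTT assay, with a stated time of 24 h (a higher number here means a weaker inhibitor, a lower number a stronger inhibitor), compound 1 (`O=C(NNc1ccccc1F)c1ccc(NS(=O)(=O)c2cnc(O)nc2O)cc1`) gives > 20000 nM as a limit of the assay and not a number. Compound 2 (`O=C(NNc1ccc(F)cc1)c1ccc(NS(=O)(=O)c2cnc(O)nc2O)cc1`) likewise gives > 20000 nM as a limit. Compound 3 (`Cc1ccc(C(=O)NNC(=O)c2ccc(NS(=O)(=O)c3cnc(O)nc3O)cc2)cc1`) also gives > 20000 nM as a limit, so it has no readable position in the series.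

The change to compound 4 (`O=C(NNC(=O)c1ccc(NS(=O)(=O)c2cnc(O)nc2O)cc1)c1ccc(F)cc1`) is fluoro in place of methyl on an aromatic carbon para to a large group. Among the measured compounds shown here, three measured steps bear on it, and none has a readable size: a step that the two limits leave unreadable from compound 1 to compound 2 and a step that the two limits leave unreadable from compound 1 to compound 3 and a step that the two limits leave unreadable from compound 2 to compound 3 all run between limits. For the measured compounds named here, the sole guide is the limit of > 20000 nM in this assay, at which 3 of the 3 values shown sit, and it gives no direction for this change. The expected step that the limit leaves unreadable from compound 3 to compound 4 in this assay is no shift beyond the scatter. Compound 4 is estimated at 30000 nM with an expected range from 15000 nM to 60000 nM in this assay and a limit is again the likely report.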

Compound 4, half-maximal inhibitory concentration: > 20000 nM
Compound 4: no number, only a limit; the forecaster's own chance of this, stated with the estimate: 85%; the middle value lies beyond the limit too.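

In this assay, among the compounds shown here, compound 4 gives > 20000 nM, a limit of the assay and not a number, so no step from compound 1, compound 2 or compound 3 to compound 4 can be read. As far as these compounds go, whether any compound on the shared core reaches a readable value in this assay stays open.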